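Adding an Ethylcarbamoyl Group to Compound 1

A few compounds are considered here, and "the series" means these few. Any claim that something is new, unique, unknown or untested is made for them only; others in the source may bear on it.

For the measured compounds named here, compound 1 `O=[N+]([O-])c1ccc2nc(CNc3ccccc3)cnc2c1` was tested in a functional assay on MCF7 cells (Homo sapiens) for cytotoxicity, read by MTT assay, with a stated time of 96 h (a lower number here means a stronger inhibitor, a higher number a weaker inhibitor), where compound 1 gives 61000 nM, the second highest of the three numbers measured so far. Compound 2 `Cc1ccc(NCc2cnc3cc([N+](=O)[O-])ccc3n2)cc1`, which carries a methyl group, gives 68000 nM in this assay, and compound 3 `O=C(O)c1ccc(NCc2cnc3cc([N+](=O)[O-])ccc3n2)cc1`, which carries a carboxy group, gives 53000 nM. The steps of a 1.1-fold higher number from compound 1 to compound 2 (0.05 log units; within the scatter) and a 1.2-fold lower number from compound 1 to compound 3 (0.06 log units; within the scatter) both stay within the scatter, as does the step of a 1.3-fold lower number from compound 2 to compound 3 (0.11 log units; within the scatter). Compound 4 `CCNC(=O)c1ccc(NCc2cnc3cc([N+](=O)[O-])ccc3n2)cc1` differs from compound 1 by ethylcarbamoyl in place of hydrogen on an aromatic carbon. For compound 4 the expected step is therefore a 1.0-fold lower number from compound 1 to compound 4 (0.01 log units; within the scatter), none beyond the scatter. Compound 4 is estimated at 60000 nM, with a range from 30000 nM to 120000 nM.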

Compound 4, half-maximal inhibitory concentration: 49000 nM
Compound 4: the middle estimate sits 1.2-fold (0.09 log units) above what was measured, within the range that was stated.
By their numbers in this assay, from the lowest: compounds 4, 3, 1 and 2 (each within the scatter of the next).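

In this assay, ethylcarbamoyl, with 5 heavy atoms and a hydrogen-bond donor and acceptor, is the largest group tried at this position, yet the number stays within the scatter (a 1.2-fold lower number from compound 1 to compound 4 (0.10 log units; within the scatter)). The comparisons with the two other substituted compounds also stay within it (a 1.1-fold lower number from compound 3 to compound 4 (0.03 log units; within the scatter); a 1.4-fold lower number from compound 2 to compound 4 (0.14 log units; within the scatter)), so compounds 1 to 4 show no measurable response to the change at this position. No evidence is available to explain this result. Still open, going by these compounds, is whether an amine or a longer chain at this position would give a step beyond the scatter.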